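Amidine series: methoxy for fluoro on the terminal ring

This account rests on a few compounds, and the source may have more. Where it says the series, first, only, none or still open, it means among the compounds named here.

Three amidines share a core and differ in the outer ring. In a functional assay on SF-295 cells (Homo sapiens) for inhibition, read by sulforhodamine B assay, with a stated time of 48 h (a higher number here means a weaker inhibitor of growth, a lower number a stronger inhibitor of growth), compound 1 `N=C(N)c1ccc(-c2ccc(-c3ccc(F)cc3)o2)o1` gives 1510 nM, compound 2 `N=C(N)c1ccc(-c2ccc(-c3ccc(Cl)cc3)s2)s1` gives 1630 nM, and compound 3 `N=C(N)c1ccc(-c2ccc(-c3ccc4ccccc4c3)s2)s1` gives 2270 nM. Compound 1 holds the smallest of the three numbers, yet its gaps to compound 2 and to compound 3 both lie within the scatter, so no ranking follows. Compound 4 `COc1ccc(-c2ccc(-c3ccc(C(=N)N)o3)o2)cc1` carries methoxy in place of fluoro on an aromatic carbon, methoxy in place of fluoro on an aromatic carbon. Among the compounds with values here, no measured pair shows this exchange, so the expected step is small, with no direction beyond the scatter. Compound 4 is estimated at 1800 nM, within 900 nM to 3600 nM, which means an expected step of a 1.2-fold higher number from compound 1 to compound 4 (0.08 log units; within the scatter) in this assay.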

Compound 4, concentration for 50% growth inhibition: 1680 nM
Estimate against measurement, compound 4: 1.1-fold (0.03 log units) above, within the range that was stated.
By their numbers in this assay, from the lowest: compounds 1, 2, 4 and 3 (each within the scatter of the next).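

In this assay, within the data shown here, methoxy in place of fluoro on an aromatic carbon, para to a large group, gives a 1.1-fold higher number from compound 1 to compound 4 (0.05 log units; within the scatter), the only matched exchange so far. Fluoro and methoxy therefore cannot be told apart at this position, even with a hydrogen-bond acceptor counted on methoxy and none on fluoro. Nothing at hand accounts for this result.

Going by these compounds, whether an amine or a carboxylic acid at this position would move the number beyond the scatter stays open. Also open, on these data alone, is whether the same exchange reads alike on the core of compound 2.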